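From Furan-2-yl to 4-Chlorophenyl: an Expected Shift

This account rests on a few compounds, and the source may have more. Where it says the series, first, only, none or still open, it means among the compounds named here.

Measured so far in a functional assay on A-431 cells (Homo sapiens) for inhibition, read by MTT assay, with a stated time of 72 h; a lower number here means a stronger inhibitor of growth, a higher number a weaker inhibitor of growth:
Compound 1 `N#C/C(=C\c1ccc(Cl)cc1)C(=O)c1ccc[nH]1` gives 52000 nM.
Compound 2 `N#C/C(=C\c1c(F)c(F)c(F)c(F)c1F)C(=O)c1c[nH]c2ccccc12` gives 19000 nM.
Compound 3 `COc1ccc(CNC(=O)/C(C#N)=C/c2ccco2)cc1` gives 16000 nM.

Compound 3 has the lowest of the three numbers. Its nearest neighbour is compound 2, whose number lies within the scatter of repeated measurements, so the two cannot be told apart. Compound 1 lies further off, beyond the scatter. Compound 4 `COc1ccc(CNC(=O)/C(C#N)=C/c2ccc(Cl)cc2)cc1` has not yet been measured in this assay. It differs from compound 3 in one place: 4-chlorophenyl in place of furan-2-yl on a double-bonded chain carbon bound to a double-bonded chain carbon. For the measured compounds named here, no pair of measured compounds shows this exact change, so no measured step can guide the expectation. Compound 1 also carries a 4-chlorophenyl group, but it differs from compound 3 in more than one place, so its value alone cannot be turned into a step. For compound 4 the expected step is of modest size toward a higher number, close to the edge of the scatter, as a 1.6-fold higher number from compound 3 to compound 4 (0.19 log units; within the scatter). Compound 4 is estimated at 25000 nM, with a range from 8000 nM to 80000 nM.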

Compound 4, concentration for 50% growth inhibition: 6000 nM
Estimate against measurement, compound 4: 4.2-fold (0.62 log units) above, outside the stated range (below it).
By their numbers in this assay, from the lowest: compound 4; then compounds 3 and 2 (each within the scatter of the next); then compound 1.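

In this assay, for the compounds shown here, 4-chlorophenyl in place of furan-2-yl on a double-bonded chain carbon bound to a double-bonded chain carbon gives a 2.7-fold lower number from compound 3 to compound 4 (0.43 log units; beyond the scatter) and stands as the first single-place comparison in this set. The step is modest but beyond the scatter, so this position does respond to the group it carries, and here the six-membered aromatic ring of carbon only goes with stronger growth inhibition than the five-membered ring with its oxygen. Nothing measured here accounts for this gain.

The compounds shown leave open whether the gain comes from the chlorine or from the six-membered ring, as a plain phenyl group is not among them. Going by these compounds alone, with only this one step, it also remains unknown how an amine or a carboxylic acid on that ring would behave.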